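Swapping Nitrophenyl for Fluoromethylphenyl under a Cytotoxicity Limit

A few compounds are considered here, and "the series" means these few. Any claim that something is new, unique, unknown or untested is made for them only; others in the source may bear on it.

The compounds were judged in an ADME assay on Vero cells (Chlorocebus sabaeus) for cytotoxicity, read by MTT assay, with a stated time of 72 h; a higher number here means that more compound is tolerated, a lower number that less compound is tolerated. Compound 1 `COC(=O)c1cc(-c2cccc(NC(=O)c3ccc(/C=C/C(=O)c4cccc(Cl)c4)cc3)c2)on1` gives only a limit there, recorded as > 2.5 ug/mL. Compound 2 `CC(C)Cc1ccc(C(=O)/C=C/c2ccc(C(=O)O)cc2)cc1` likewise gives a limit, < 10 ug/mL. Compound 3 `COC(=O)c1cc(-c2cccc(NC(=O)c3ccc(/C=C/C(=O)c4cccc([N+](=O)[O-])c4)cc3)c2)on1` also gives a limit, > 40 ug/mL. Compound 3 thus stands only as a limit and not a number, and the two further values shown are limits as well. Going by the values given here, the one pair that differs in a single place, compound 1 and compound 3, gives a step that the two limits leave unreadable from compound 1 to compound 3, so no measured step can be read in this assay at all; what the evidence holds is the limit of < 10 ug/mL in this assay, at which 1 of the 3 values shown sits, the limit of > 2.5 ug/mL in this assay, at which 1 of the 3 values shown sits, and (the limit of > 40 ug/mL in this assay, at which 1 of the 3 values shown sits).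

Compound 4 `COC(=O)c1cc(-c2cccc(NC(=O)c3ccc(/C=C/C(=O)c4ccc(C)c(F)c4)cc3)c2)on1` differs from compound 3 by 3-fluoro-4-methylphenyl in place of 3-nitrophenyl on a carbonyl carbon. Among the compounds with values here, no measured step bears on this change, and the single step between measured compounds is unreadable. The only anchor is the limit of compound 3 described by the limit of > 40 ug/mL in this assay, at which 1 of the 3 values shown sits. Compound 4 is therefore expected to show a step of a number no higher from compound 3 to compound 4 (the limit leaves the size open), with no direction that can be claimed beyond the scatter. Compound 4 is estimated at 40 ug/mL in this assay, between 15 ug/mL and 110 ug/mL, and it is likely that only a limit is reported again.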

Compound 4, half-maximal cytotoxic concentration: > 50 ug/mL
Compound 4 was reported as a limit; the forecaster's own chance of this, stated with the estimate: 60%; middle value at least 1.2-fold (0.09 log units) from the limit.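

In this assay compound 4 gives only a limit, > 50 ug/mL, and not a number. Compound 3 gives a limit too, > 40 ug/mL, and neither the step from compound 3 to compound 4 nor that from compound 1 to compound 4 can be read. The compounds shown leave open whether 3-fluoro-4-methylphenyl changes tolerance relative to 3-nitrophenyl or 3-chlorophenyl, and in which direction.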